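Para Substituent Restored on the Pyrazinone Aryl Ring

The source may hold more compounds than are shown below. What is called first, only, known or untested is meant among the compounds shown, and "the series" means these compounds.

Compound 2 `Cc1cc(=O)n(-c2cccc(F)c2)nc1C(=O)Nc1ccc(Oc2ncnc3c2ccn3C)c(F)c1` is known in a functional assay on A549 cells (Homo sapiens) for cytotoxicity, read by MTT assay, with a stated time of 72 h (a lower number here means a stronger inhibitor, a higher number a weaker inhibitor), only as a limit, > 60000 nM, with no number behind it. Compound 1 `Cc1cc(=O)n(-c2ccc(Br)cc2F)nc1C(=O)Nc1ccc(Oc2ncnc3c2ccn3C)c(F)c1` gives 14400 nM in this assay. Among the measured compounds shown here, the only measured step, an at least 4.1-fold higher number from compound 1 to compound 2 (0.61 log units; beyond the scatter), is the sole guide, and the limit of > 60000 nM in this assay, at which 1 of the 2 values shown sits, marks where compound 2 sits. Compound 3 `Cc1ccc(-n2nc(C(=O)Nc3ccc(Oc4ncnc5c4ccn5C)c(F)c3)c(C)cc2=O)cc1` differs from compound 2 by 4-methylphenyl in place of 3-fluorophenyl on an aromatic nitrogen. Because the measured step of an at least 4.1-fold higher number from compound 1 to compound 2 (0.61 log units; beyond the scatter) weakened the number once a para group was removed, compound 3 is expected to recover part of it, though the limit for compound 2 leaves the size uncertain. Compound 3 is estimated at 30000 nM, between 9000 nM and 70000 nM. That implies an expected step of an at least 2.0-fold lower number from compound 2 to compound 3 (0.30 log units; that floor lies within the scatter).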

Compound 3, half-maximal inhibitory concentration: > 60000 nM
Compound 3: no number, only a limit; the forecaster's own chance of this, stated with the estimate: 40%; middle value at least 2.0-fold (0.30 log units) from the limit.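

In this assay, 4-methylphenyl on this aromatic nitrogen gives no measurable number, so a methyl group on the aryl ring does not do what the 4-bromo-2-fluorophenyl group of compound 1 does, with an at least 4.1-fold higher number from compound 1 to compound 3 (0.61 log units; beyond the scatter). Compound 3 is known only as a limit, as compound 2 is: the limit of > 60000 nM in this assay, at which 2 of the 3 values shown sit. The step between those two compounds cannot be read. On these data alone, it stays open whether 4-chlorophenyl or 4-methoxyphenyl would give a number here, and whether the bromine or the fluorine of compound 1 matters more.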